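Working notes: bromo to trifluoromethyl in the series

The source may report more compounds than this note shows. Statements on the series, on what has been measured and on what is new or still open speak of the compounds shown alone.

- compound 1 `O=C(Nc1ccc(NCc2ccc(Cl)cc2)cc1Cl)c1cc(Cl)ccc1O`: 59700 nM
- compound 2 `O=C(Nc1ccc(NCc2ccc(Br)cc2)cc1Cl)c1cc(Cl)ccc1O`: 40900 nM

In an ADME assay on A549 cells (Homo sapiens) for cytotoxicity, read by resazurin assay, with a stated time of 48 h (a lower number here means that less compound is tolerated, a higher number that more compound is tolerated), compound 2 gives 40900 nM, which lies within the scatter of compound 1 at 59700 nM. The two compounds therefore offer a single level of tolerance to work from, with no order between them.

The next compound, compound 3 `O=C(Nc1ccc(NCc2ccc(C(F)(F)F)cc2)cc1Cl)c1cc(Cl)ccc1O`, carries trifluoromethyl in place of bromo on an aromatic carbon, para to a large group: trifluoromethyl in place of bromo on an aromatic carbon.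

For the measured compounds named here, one measured step bears on this change: a 1.5-fold lower number from compound 1 to compound 2 (0.16 log units; within the scatter), bromo in place of chloro on an aromatic carbon. Going by the values given here, that step exchanges one halogen for another, and no measured compound here carries trifluoromethyl, so it is only a loose guide. On that single step, no change beyond the scatter is expected, and no direction can be favoured.

The expected step is a 1.1-fold higher number from compound 2 to compound 3 (0.04 log units; within the scatter). For compound 3 the estimate is 45000 nM, with an expected range of 20000 nM to 95000 nM.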

Compound 3, half-maximal cytotoxic concentration: 62700 nM
Compound 3: the middle estimate sits 1.4-fold (0.14 log units) below what was measured, and the stated range covers the measured number.
By their numbers in this assay, from the lowest: compounds 2, 1 and 3 (each within the scatter of the next).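

Trifluoromethyl is the first group at this place, on an aromatic carbon para to a large group, that is not a single halogen atom, and in this assay the exchange for bromo gives a 1.5-fold higher number from compound 2 to compound 3 (0.19 log units; within the scatter), while the exchange for chloro gives a 1.1-fold higher number from compound 1 to compound 3 (0.02 log units; within the scatter). For the compounds shown here, the earlier pair compared only two halogens; with this third group, which has more heavy atoms than either, all three compounds still sit at a single level of tolerance, with no order among them and no compound going against that reading. Nothing available gives a cause for this flat result.

The compounds shown leave open whether any group at this place can move the number beyond the scatter, since all three substituents carry no hydrogen-bond donors or acceptors and no net charge, unlike an amine or a carboxylic acid. They also leave open how plain hydrogen or a longer chain, such as butyl, would compare with this level of tolerance.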